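Notes on compound 4: difluorophenyl for aminophenyl on the ketone

The source may hold more compounds than are shown below. What is called first, only, known or untested is meant among the compounds shown, and "the series" means these compounds.

Three members of the series have numbers in a functional assay on Hs-578T cells (Homo sapiens) for cytotoxicity, read by sulforhodamine B assay, with a stated time of 48 h, tested at 0.1 uM; a lower number here means a stronger effect, a higher number a weaker effect of the compound at the concentration tested. Compound 1 `COc1cc(-c2cc(/C=C/C(=O)c3ccc(N)cc3)[nH]n2)cc(OC)c1OC` gives 88% in this assay. Compound 2 `COc1ccc(-c2cc(/C=C/C(=O)c3cc(OC)c(OC)c(OC)c3)[nH]n2)cc1OC` gives 97%, and compound 3 `COc1cc(C(=O)/C=C/c2cc(-c3cc(OC)c(OC)c(OC)c3)n[nH]2)cc(OC)c1OC` gives 90%. Within the data shown here, the one measured step between single-point neighbours, a number 7 percentage points lower from compound 2 to compound 3 (within the scatter), is the only guide to how much this read-out moves, and it does not move beyond the scatter. Compound 1 stands at the low end of the three numbers, but neither compound 3 nor compound 2 is separated from it by more than the scatter, so all three read as weak effects at this concentration.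

Compound 4 `COc1cc(-c2cc(/C=C/C(=O)c3ccc(F)c(F)c3)[nH]n2)cc(OC)c1OC` is not yet measured. It differs from compound 1 in one place: 3,4-difluorophenyl in place of 4-aminophenyl on a carbonyl carbon. Among the measured compounds shown here, no measured step in this assay concerns the aryl group on the carbonyl carbon; the step from compound 2 to compound 3 touches a different ring and was within the scatter. For the measured compounds named here, with every number so far high and close together, the expectation for compound 4 is a read-out in the same band, with a number 2 percentage points higher from compound 1 to compound 4 (within the scatter) expected to stay within the scatter. The estimate for compound 4 is therefore 90%, with a range from 76% to 102%.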

Compound 4, a percentage reported as activity, at one concentration (the size of the read-out at that concentration, not a potency): 97%
For compound 4 the middle estimate is 7 percentage points below the measured one, and the stated range covers the measured number.
By their numbers in this assay, from the lowest: compounds 1, 3, 2 and 4 (each within the scatter of the next).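

In this assay, among these compounds, the aryl group on the carbonyl carbon is now probed directly for the first time: 3,4-difluorophenyl in place of 4-aminophenyl gives a number 9 percentage points higher from compound 1 to compound 4 (within the scatter). This change removes the hydrogen-bond donor and acceptor counted on 4-aminophenyl and replaces the nitrogen with two fluorines, yet the two compounds are not separated at this concentration, so this single exchange gives no sign that the read-out depends on the aryl group at this position. Nothing available bears on why the read-out stays flat across this change.

From the compounds shown here alone, it remains open whether a different group on this aryl ring, such as a carboxylic acid, a nitrile or a morpholine, or a longer alkyl chain in place of the ring, would move the number beyond the usual scatter. Going by these compounds, with a single concentration and a single cell line, and with every compound shown sitting high in the same narrow band, it also remains open whether compound 1 and compound 4 would separate under other conditions, or whether this position matters for cytotoxicity at all.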